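The source may hold more compounds than are shown below. What is called first, only, known or untested is meant among the compounds shown, and "the series" means these compounds.

Measured compounds:
compound 1 `COC(=O)C1=C(C)N=C(C)/C(=C(\O)OC)C1c1ccccc1N` 39800 nM
compound 2 `COC(=O)C1=C(C)N=C(C)/C(=C(\O)OC)C1c1ccccc1I` 46.8 nM
compound 3 `CCc1ccccc1C1C(C(=O)OC)=C(C)N=C(C)/C1=C(\O)OC` 6.46 nM

In a functional assay (muscle tissue) with Cavia porcellus as the target (a higher number here means that more compound is needed for the effect, a lower number that less compound is needed), compound 3 stands lowest of the three; compound 2 lies nearest, compound 1 furthest.

Compound 4 `COC(=O)C1=C(C)N=C(C)/C(=C(\O)OC)C1c1ccc(C#N)cc1` differs from compound 3 in one place: 4-cyanophenyl in place of 2-ethylphenyl on a saturated ring carbon. Among the compounds with values here, no measured step covers this change. The steps that exist all alter the group on the aromatic ring in one spot: an 850-fold lower number from compound 1 to compound 2 (2.93 log units; beyond the scatter), a 6200-fold lower number from compound 1 to compound 3 (3.79 log units; beyond the scatter), a 7.2-fold lower number from compound 2 to compound 3 (0.86 log units; beyond the scatter). They show that this group sets the number strongly, so a step beyond the scatter is expected in this assay for compound 4, most probably toward a higher number, with wide uncertainty; the estimated step is a 46-fold higher number from compound 3 to compound 4 (1.67 log units; beyond the scatter). For compound 4 the expected value is 300 nM, range 30 nM to 3000 nM.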

Compound 4, half-maximal effective concentration: 3470 nM
Compound 4: middle estimate off by 12-fold (1.06 log units), on the low side; measured number outside the range, above it.
By their numbers in this assay, from the lowest: compound 3; then compound 2; then compound 4; then compound 1.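

In this assay the 4-cyanophenyl group gives a 540-fold higher number from compound 3 to compound 4 (2.73 log units; beyond the scatter) and a 74-fold higher number from compound 2 to compound 4 (1.87 log units; beyond the scatter), so a group with a nitrile at this place does not reach the low numbers of the 2-ethylphenyl and 2-iodophenyl groups. It still gives an 11-fold lower number from compound 1 to compound 4 (1.06 log units; beyond the scatter), which places it between those groups and 2-aminophenyl. Nothing measured here explains these steps.

The compounds shown do not separate the nitrile from its location on the aromatic ring. A 2-cyanophenyl or 4-ethylphenyl group would address that question.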